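A few compounds are considered here, and "the series" means these few. Any claim that something is new, unique, unknown or untested is made for them only; others in the source may bear on it.

Compound 1 `O[C@H]1[C@H](O)CN[C@@H]1c1ccc(F)cc1` — 2%
Compound 2 `Cc1ccc([C@H]2NC[C@@H](O)[C@@H]2O)cc1` — 0%
Compound 3 `Cc1ccc([C@@H]2NC[C@H](O)[C@H]2O)cc1` — 0%

In an assay on isolated protein for inhibition of alpha-galactosidase (Coffea arabica), read by spectrophotometry, tested at 1000 uM (a lower number here means less inhibition, a higher number more inhibition at the concentration tested (going by the name of the read-out)), compound 3 stands level with compound 2 at the digits shown, the two together at the bottom of the three numbers; the two steps that run through these three numbers are a number 2 percentage points lower from compound 1 to compound 2 (within the scatter) followed by no change at the digits printed from compound 2 to compound 3 (within the scatter), both within the scatter. The step of no change at the digits printed from compound 2 to compound 3 (within the scatter) goes with the fact that compounds 2 and 3 differ only in the configuration as drawn. Compound 4 `O[C@@H]1[C@@H](O)CN[C@H]1c1ccc(F)cc1` is the next member: fluoro in place of methyl on an aromatic carbon. Among the measured compounds shown here, the one measured step that bears on this change is a number 2 percentage points lower from compound 1 to compound 2 (within the scatter), the same exchange run the other way, and it lay within the scatter. No step beyond the scatter is therefore expected here, a number 1 percentage points higher from compound 3 to compound 4 (within the scatter). Compound 4 is estimated at 1%, with a range from -5% to 8%.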

Compound 4, a percentage reported as inhibition, at one concentration (the size of the read-out at that concentration, not a potency): 16.6%
Compound 4: the middle estimate sits 15.6 percentage points below what was measured; measured number above the stated range.
By their numbers in this assay, from the lowest: compounds 2, 3 and 1 (each within the scatter of the next); then compound 4.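

In this assay, fluoro in place of methyl at this position does register on one core, a number 16.6 percentage points higher from compound 3 to compound 4 (beyond the scatter), although the same exchange stayed within the scatter on the mirror-image core. The effect of this exchange therefore depends on the configuration of the core that carries it: the same change on two cores in this assay, a number 2 percentage points lower (within the scatter) from compound 1 to compound 2 and a number 16.6 percentage points lower (beyond the scatter) from compound 4 to compound 3, 14.6 percentage points apart, beyond the scatter of two such steps Configuration also separates the two fluoro compounds, a number 14.6 percentage points higher from compound 1 to compound 4 (beyond the scatter), a difference not seen between the two methyl compounds: the fact that compounds 1 and 4 differ only in the configuration as drawn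

As far as these compounds go, whether chloro or methoxy at this position would follow fluoro or methyl remains open. A reading at one concentration also gives no potency for compound 4.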